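Swapping the nitro group on the aryloxy ring of compound 3

The compounds below may be only part of what the source reports. "The series", "measured", "known", "first", "only" and "open" are said of these compounds alone.

Measured so far in an assay on HEK293 cells for inhibition of N-acylethanolamine-hydrolyzing acid amidase (Homo sapiens), read by fluorescence, with stated times of 10 min and 50 min; on this read-out lower numbers stand for stronger inhibition and higher numbers for weaker inhibition:
compound 1 `CCCCCCCON1C(=O)[C@@H](NC(=O)OCCCCC2CCCCC2)[C@@H]1C` gives 2230 nM
compound 2 `C[C@H]1[C@H](NC(=O)OCCCCC2CCCCC2)C(=O)N1Oc1ccccc1` gives 23 nM
compound 3 `C[C@H]1[C@H](NC(=O)OCCCCC2CCCCC2)C(=O)N1Oc1ccc([N+](=O)[O-])cc1` gives 17 nM

Compound 3 has the lowest of the three numbers, but its gap to compound 2 lies within the scatter, so the two cannot be ranked; only compound 1 stands clearly apart, as the steps of a 97-fold lower number from compound 1 to compound 2 (1.99 log units; beyond the scatter) and a 130-fold lower number from compound 1 to compound 3 (2.12 log units; beyond the scatter) show. The next compound, compound 4 `COC(=O)c1ccc(ON2C(=O)[C@@H](NC(=O)OCCCCC3CCCCC3)[C@@H]2C)cc1`, differs from compound 3 in one place: methoxycarbonyl in place of nitro on an aromatic carbon. The step that bears on this is a 1.4-fold lower number from compound 2 to compound 3 (0.13 log units; within the scatter), which shows that putting a nitro group onto the aromatic ring, para to a large group, changed the number only within the scatter. Since both the nitro and the methoxycarbonyl group sit on that same aromatic carbon, and the aromatic ring itself was what moved the number away from compound 1, no step beyond the scatter is expected for a 1.2-fold higher number from compound 3 to compound 4 (0.07 log units; within the scatter). Compound 4 is therefore estimated at 20 nM, with a likely range from 8 nM to 50 nM.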

Compound 4, half-maximal inhibitory concentration: 17 nM
Compound 4: middle estimate off by 1.2-fold (0.07 log units), on the high side; the range from low to high includes it.
By their numbers in this assay, from the lowest: compounds 3, 4 and 2 (each within the scatter of the next); then compound 1.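

Methoxycarbonyl in place of nitro on this aromatic carbon, para to a large group, gives no change at the digits printed from compound 3 to compound 4 (within the scatter) and so shows that a second, different group can sit here with the number staying put. Set against the plain ring with hydrogen at that carbon, the new group gives a 1.4-fold lower number from compound 2 to compound 4 (0.13 log units; within the scatter) and so hydrogen, nitro and methoxycarbonyl cannot be told apart at this place. The large gap stays with the group on the oxygen, as a 130-fold lower number from compound 1 to compound 4 (2.12 log units; beyond the scatter) shows for 4-(methoxycarbonyl)phenyl in place of heptyl.

Still open, from the compounds shown here alone, is whether an amine or a carboxylic acid on this carbon, or any group on another carbon of the ring, would also stay within the scatter. No measurement shown here explains why these compounds read alike.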